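Swapping the amide substituent at the end of a cyclopropyl side chain

This account rests on a few compounds, and the source may have more. Where it says the series, first, only, none or still open, it means among the compounds named here.

Measured so far:
- compound 1, `Cc1nc(-c2ccc(C(F)(F)F)cc2)sc1CNc1ccc(/C=C/C(=O)O)cc1`: 36.3 nM
- compound 2, `Cc1nc(-c2ccc(C(F)(F)F)cc2)sc1CNc1ccc([C@H]2C[C@@H]2C(=O)NC2CCNC2)cc1`: 204 nM

Both compounds were tested in a functional assay on CHO cells for agonist activity at Free fatty acid receptor 1 (Homo sapiens); a lower number here means that less compound is needed, a higher number that more compound is needed for the effect. Compound 2 has the highest number of the two; its nearest neighbour is compound 1, and the step of a 5.6-fold higher number from compound 1 to compound 2 (0.75 log units; beyond the scatter) lies beyond the scatter.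

Compound 3, `Cc1nc(-c2ccc(C(F)(F)F)cc2)sc1CNc1ccc([C@H]2C[C@@H]2C(=O)NO)cc1`, has not been measured yet. It differs from compound 2 in one place: hydroxy in place of pyrrolidin-3-yl on an amide-type nitrogen.

Going by the values given here, the only measured step, from compound 1 to compound 2, changed the whole side chain on the aromatic carbon, not just the group on the amide nitrogen, so it bears on the present change only loosely. It shows that this part of the molecule can shift the number by a modest amount. Nothing measured here speaks directly to a hydroxy on the amide nitrogen. A modest change is therefore expected, with the direction open, and for compound 3 the estimate is 120 nM, within the range 35 nM to 450 nM, which means an expected step of a 1.7-fold lower number from compound 2 to compound 3 (0.23 log units; within the scatter).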

Compound 3, half-maximal effective concentration: 6.92 nM
Compound 3: the middle estimate sits 17-fold (1.24 log units) above what was measured, and the stated range ends above it.
By their numbers in this assay, from the lowest: compound 3; then compound 1; then compound 2.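

In this assay, going by these compounds alone, the group on the amide nitrogen matters far more than the one earlier step could show: exchanging pyrrolidin-3-yl for hydroxy, with the rest of the molecule unchanged, gives a 29-fold lower number from compound 2 to compound 3 (1.47 log units; beyond the scatter) in a single move. The 2-(hydroxycarbamoyl)cyclopropyl side chain also improves on 2-carboxyethenyl, giving a 5.2-fold lower number from compound 1 to compound 3 (0.72 log units; beyond the scatter) and the lowest number of the three compounds, so a free carboxylic acid is not needed on this side chain for a low number here. Nothing at hand explains why the hydroxy does so much better than the pyrrolidin-3-yl group.

The compounds shown leave open whether the gain depends on the hydroxy itself or only on the loss of the pyrrolidin-3-yl ring, a question that a methoxy or a methyl group on the same nitrogen would help to settle. They also leave open how much of the difference between the two side chains comes from the cyclopropyl part and how much from the hydroxycarbamoyl end, which a cyclopropyl chain ending in a carboxylic acid would begin to separate.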